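Trimming cyclohexyl to methyl on the benzimidazole of compound 1

The source may report more compounds than this note shows. Statements on the series, on what has been measured and on what is new or still open speak of the compounds shown alone.

Measured compounds:
compound 1, `CCCCOC(=O)NS(=O)(=O)c1ccc(CCC)cc1-c1ccc(Cn2c(C3CCCCC3)nc3ccccc32)cc1`, 130 nM
compound 2, `CCCc1ccc(S(=O)(=O)NC(=O)OCCCC(F)(F)F)c(-c2cc(F)c(Cn3c(C(C)(C)C)nc4ccccc43)c(F)c2)c1`, 12 nM
compound 3, `CCCc1ccc(S(=O)(=O)NC(=O)OCCCC(F)(F)F)c(-c2ccc(Cn3c(C(C)(C)C)nc4ccccc43)cc2)c1`, 4.5 nM

In an assay on membranes from HEK293 cells for displacement of a labelled ligand from Type-2 angiotensin II receptor (Homo sapiens), read by radioligand binding (on this read-out lower numbers stand for stronger inhibition and higher numbers for weaker inhibition), compound 1 stands highest of the three numbers. Among the measured compounds shown here, compound 2 and compound 3 both lie well below it, beyond the scatter, but each differs from compound 1 in more than one place, so no single step between measured compounds can be read from them.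

Compound 4, `CCCCOC(=O)NS(=O)(=O)c1ccc(CCC)cc1-c1ccc(Cn2c(C)nc3ccccc32)cc1`, is not yet measured. It differs from compound 1 only by methyl in place of cyclohexyl on an aromatic carbon. For the measured compounds named here, no measured pair isolates this change, so the expectation rests on the size of the group removed. A step towards a weaker, higher number is expected, a 3.5-fold higher number from compound 1 to compound 4 (0.54 log units; beyond the scatter), lying beyond the scatter. Compound 4 is estimated at 450 nM, with a range from 120 nM to 2000 nM.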

Compound 4, inhibition constant: 9.4 nM
The estimate for compound 4 lay 48-fold (1.68 log units) above the measured number, outside the stated range (below it).
By their numbers in this assay, from the lowest: compound 3; then compounds 4 and 2 (each within the scatter of the next); then compound 1.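

In this assay, methyl in place of cyclohexyl on the aromatic carbon between two ring nitrogen atoms gives a 14-fold lower number from compound 1 to compound 4 (1.14 log units; beyond the scatter) and shows that a large group at this position is not needed for strong inhibition. On this core, the smaller group is clearly the better of the two. Nothing measured here accounts for the step.

Only cyclohexyl and methyl can be compared directly at this position on this core. An ethyl, an isopropyl or a phenyl group there could show whether the number rises steadily with group size or changes abruptly between particular groups.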